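The compounds below may be only part of what the source reports. "The series", "measured", "known", "first", "only" and "open" are said of these compounds alone.

Compound 1 `COc1cc(-c2nn(-c3cccc(NC(=O)c4cccc(C(F)(F)F)c4)c3)cc2-c2ccncc2)ccc1Cl` stands at the limit of a functional assay on NCI-H226 cells (Homo sapiens) for inhibition, read by sulforhodamine B assay, with a stated time of 48 h; on this read-out lower numbers stand for higher toxicity in this test and higher numbers for lower toxicity in this test: in this assay compound 1 gives > 50000 nM, which is a limit of the test rather than a number, as the limit of > 50000 nM in this assay, at which 1 of the 2 values shown sits, shows. Compound 2 `O=C(Nc1cccc(-n2cc(-c3ccncc3)c(-c3ccc(Cl)c(O)c3)n2)c1)Nc1cc(C(F)(F)F)cc(C(F)(F)F)c1`, measured alongside, gives in this assay 37600 nM. Compound 3 `COc1cc(-c2nn(-c3cccc(NC(=O)Nc4ccc(Cl)c(C(F)(F)F)c4)c3)cc2-c2ccncc2)ccc1Cl` differs from compound 1 by (4-chloro-3-(trifluoromethyl)phenyl)amino in place of 3-(trifluoromethyl)phenyl on a carbonyl carbon. Within the data shown here, no measured pair follows this exact change, so the expected step is an at least 1.4-fold lower number from compound 1 to compound 3 (0.15 log units; that floor lies within the scatter), a small shift toward higher toxicity that may not pass the scatter, since compound 2 reaches a number at 37600 nM. Compound 3 is therefore estimated at 35000 nM, within 15000 nM to 50000 nM.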

Compound 3, concentration lethal to 50% of the cells: > 32500 nM
Compound 3: only a limit was reported; the forecaster's own chance of this, stated with the estimate: 45%; the middle value lies beyond the limit too.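

Compound 1 and compound 3 both stand at limits of the test rather than at numbers, so no step can be read between them. The compounds shown leave open whether (4-chloro-3-(trifluoromethyl)phenyl)amino in place of 3-(trifluoromethyl)phenyl changes the result in this assay at all.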